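Compound 4: a Heteroaryl Replacement Traced from Compound 1

The source may report more compounds than this note shows. Statements on the series, on what has been measured and on what is new or still open speak of the compounds shown alone.

Measured compounds:
compound 1 `Cc1cc(Nc2ccn(Cc3cccc4ccccc34)n2)n2nc(SCc3ccc(Br)cc3)nc2n1`: 3240 nM
compound 2 `Cc1ccc(CSc2nc3nc(C)cc(Nc4cc(-c5ccccc5)[nH]n4)n3n2)cc1`: 6960 nM
compound 3 `Cc1cc(Nc2cc(-c3ccccc3)[nH]n2)n2nc(SCc3csc4ccccc34)nc2n1`: 2280 nM

In a functional assay on MGC-803 cells (Homo sapiens) for inhibition, read by MTT assay, with a stated time of 72 h (a higher number here means a weaker inhibitor, a lower number a stronger inhibitor), compound 1 gives 3240 nM, the second highest of the three numbers. Its gap to compound 3 lies within the scatter, while compound 2 sits higher by a margin beyond it. Compound 4 `Cc1cc(Nc2ccn(Cc3nc(C)c4ccccc4n3)n2)n2nc(SCc3ccc(Br)cc3)nc2n1` is compound 1 with one change: 4-methylquinazolin-2-yl in place of naphthalen-1-yl on a saturated chain carbon bound to an aromatic nitrogen. Among the measured compounds shown here, the only measured step, a 3.1-fold lower number from compound 2 to compound 3 (0.48 log units; beyond the scatter), concerns the group on the sulfur-bound carbon, a different place, so no measured step bears on the change in compound 4. No shift beyond the scatter is therefore expected, and the expected step is a 1.0-fold lower number from compound 1 to compound 4 (0.01 log units; within the scatter). Compound 4 is estimated at 3200 nM, within a range from 1000 nM to 10000 nM.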

Compound 4, half-maximal inhibitory concentration: 960 nM
Estimate against measurement, compound 4: 3.3-fold (0.52 log units) above; measured number outside the range, below it.
By their numbers in this assay, from the lowest: compound 4; then compounds 3 and 1 (each within the scatter of the next); then compound 2.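

In this assay, among the compounds shown here, the step of a 3.4-fold lower number from compound 1 to compound 4 (0.53 log units; beyond the scatter) is the first measured at the saturated chain carbon bound to an aromatic nitrogen, and it shows that the group held there can shift the number. The change swaps a ring pair of carbon only for one with 2 hetero atoms and adds a methyl group. No measurement at hand accounts for the step. The compounds shown leave open whether the ring nitrogens or the methyl group carries it, which a plain quinazolin-2-yl would help separate. On these data alone, whether it persists with 1-benzothiophen-3-yl on the sulfur-bound carbon also remains open.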